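Estimating Compound 4 From Three Measured Analogues

A few compounds are considered here, and "the series" means these few. Any claim that something is new, unique, unknown or untested is made for them only; others in the source may bear on it.

Compound 1, `CCOC(=O)C1=C(N/C=N/c2cccnc2Cl)Nc2[nH]nc(C)c2C1c1ccc(N(C)C)cc1`, gives in a functional assay on HepG2 cells (Homo sapiens) for inhibition, read by MTT assay, with a stated time of 48 h (a higher number here means a weaker inhibitor, a lower number a stronger inhibitor), a value of 4890 nM.
Compound 2, `CCOC(=O)C1=C(N/N=C(\C#N)C(N)=O)Nc2[nH]nc(C)c2C1c1ccc(N(C)C)cc1`, gives in this assay a value of 48400 nM.
Compound 3, `CCOC(=O)C1=C(N/C=N/c2ccc([N+](=O)[O-])cc2)Nc2[nH]nc(C)c2C1c1ccc(N(C)C)cc1`, gives in this assay a value of 50900 nM.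

Compound 3 stands at the highest number of the three. Its separation from compound 1 is real, as the step of a 10-fold higher number from compound 1 to compound 3 (1.02 log units; beyond the scatter) shows, but against compound 2 the step of a 1.1-fold higher number from compound 2 to compound 3 (0.02 log units; within the scatter) lies within the scatter, so compound 2 and compound 3 cannot be ranked against each other.

Compound 4, `CCOC(=O)C1=C(N/N=C(/C(=O)Br)c2ccc(Cl)cc2)Nc2[nH]nc(C)c2C1c1ccc(N(C)C)cc1`, is not yet measured. Its change from compound 3 is a group of 12 heavy atoms (8 carbon, 1 nitrogen, 1 oxygen, 1 chlorine, 1 bromine; one six-membered aromatic ring of carbon only) in place of a group of 11 heavy atoms (7 carbon, 2 nitrogen, 2 oxygen; one six-membered aromatic ring of carbon only), on an amine nitrogen.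

Going by the values given here, two measured steps bear on this. The step of a 9.9-fold higher number from compound 1 to compound 2 (1.00 log units; beyond the scatter) and the step of a 10-fold higher number from compound 1 to compound 3 (1.02 log units; beyond the scatter) show that two very different replacements at this amine nitrogen each weakened the inhibitor by about the same amount, and the step of a 1.1-fold higher number from compound 2 to compound 3 (0.02 log units; within the scatter) shows those two replacements ending at the same number. Nothing here compares two groups that both carry a six-membered aromatic ring of carbon only, so a flat outcome is the simplest expectation. The step of a 1.5-fold lower number from compound 3 to compound 4 (0.16 log units; within the scatter) is therefore expected to stay within the scatter. Compound 4 is estimated at 35000 nM, with a range from 9000 nM to 120000 nM.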

Compound 4, half-maximal inhibitory concentration: 50300 nM
The estimate for compound 4 lay 1.4-fold (0.16 log units) below the measured number; the measured number falls inside the stated range.
By their numbers in this assay, from the lowest: compound 1; then compounds 2, 4 and 3 (each within the scatter of the next).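

Going by these compounds alone, the group in compound 4 and the one in compound 3 each carry a six-membered aromatic ring of carbon only, and the first direct comparison of two such groups at this amine nitrogen, a 1.0-fold lower number from compound 3 to compound 4 (0.01 log units; within the scatter), shows no readable change, even though the groups differ in their other atoms, with chlorine and bromine present only in compound 4. The step of a 1.0-fold higher number from compound 2 to compound 4 (0.02 log units; within the scatter) also stays within the scatter, although the group in compound 2 has no ring, so three quite different groups now cannot be ranked against one another in this assay, while a 10-fold higher number from compound 1 to compound 4 (1.01 log units; beyond the scatter) leaves compound 1 as the only one of the four set clearly apart, with the strongest inhibition. No measurement shown explains why these three compounds match or why compound 1 differs.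

The compounds shown do not tell whether the ring nitrogen or the chlorine of the 2-chloropyridin-3-yl group goes with the lower number of compound 1. As far as these compounds go, a plain phenyl or an unsubstituted pyridin-3-yl group at this amine nitrogen would bear on that question, and how either would read here remains open.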